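Dichloro to Monochloro: One Aromatic Hydrogen Replaces Chlorine

The source may hold more compounds than are shown below. What is called first, only, known or untested is meant among the compounds shown, and "the series" means these compounds.

Compound 1 `O=C(O)/C=C/C(=O)c1ccc(Cl)c(Cl)c1` has the highest number among the three compounds measured in a functional assay on LS174T cells (Homo sapiens) for inhibition, read by MTT assay, with a stated time of 72 h; a higher number here means a weaker inhibitor, a lower number a stronger inhibitor: compound 1 gives 32300 nM. Compound 2 `CC(C)c1ccc(C(C)C)c(C(=O)/C=C/C(=O)O)c1` gives 6230 nM and compound 3 `CCc1cc(CC)c(C(=O)/C=C/C(=O)O)c(CC)c1` gives 7280 nM, both lower than compound 1 by margins beyond the scatter. Compound 4 `O=C(O)/C=C/C(=O)c1ccc(Cl)cc1` differs from compound 1 in one place: hydrogen in place of chloro on an aromatic carbon. Going by the values given here, no measured pair in this set shows the effect of this change, so the expectation rests on compound 1 alone. Removing a chloro group is expected to give a step of a 1.2-fold higher number from compound 1 to compound 4 (0.09 log units; within the scatter), small and possibly within the scatter, with little reason to expect a gain. Compound 4 is therefore estimated at 40000 nM, in a range from 12000 nM to 130000 nM.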

Compound 4, half-maximal inhibitory concentration: 28700 nM
Compound 4: the middle estimate sits 1.4-fold (0.14 log units) above what was measured; low and high end bracket the measured number.
By their numbers in this assay, from the lowest: compounds 2 and 3 (each within the scatter of the next); then compounds 4 and 1 (each within the scatter of the next).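

Replacing chloro with hydrogen on this aromatic carbon, ortho to a chloro group, gives a 1.1-fold lower number from compound 1 to compound 4 (0.05 log units; within the scatter) in this assay. Going by these compounds alone, this is the only one-place comparison in the set, and it shows that this chloro group can be lost with no change that can be read beyond the scatter. Nothing measured here accounts for this result. The compounds shown leave open whether an amine, a methoxy group or a longer chain on this same carbon would move the number beyond the scatter. They also leave open what replacing the remaining chloro group with hydrogen would do.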